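A few compounds are considered here, and "the series" means these few. Any claim that something is new, unique, unknown or untested is made for them only; others in the source may bear on it.

Among the measured compounds shown here, in a functional assay on the whole organism (Tail) for activation, with Mus musculus as the target, with a stated time of 1 min (a higher number here means that more compound is needed for the effect, a lower number that less compound is needed), two compounds have numbers so far. Compound 1 (`N#Cc1ccc(-c2ccc(/C=N/N3C(=O)NC(=O)C3O)o2)cc1`) gives 743 mg/kg and compound 2 (`O=C1CN(/N=C/c2ccc(-c3cccc(C(F)(F)F)c3)o2)C(=O)N1`) gives 184 mg/kg as the lower of the two, a gap beyond the scatter. Compound 3 (`O=C1NC(=O)N(/N=C/c2ccc(-c3cccc(C(F)(F)F)c3)o2)C1O`) differs from compound 2 by one change (hydroxy in place of hydrogen on a saturated ring carbon) with hydroxy in place of hydrogen on a saturated ring carbon. For the measured compounds named here, no measured pair isolates this change, so its size cannot be read from the data. Compound 1 also carries the 5-hydroxy-2,4-dioxoimidazolidin-1-yl group and gives 743 mg/kg but it differs from compound 2 elsewhere too, which makes it only a weak guide. A modest rise in the number is expected, near the edge of the scatter. The expected step is a 1.8-fold higher number from compound 2 to compound 3 (0.27 log units; within the scatter) and would mean that more compound is needed. For compound 3 the estimated dose is 340 mg/kg with 150 mg/kg to 800 mg/kg as the expected range.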

Compound 3, dose for half-maximal effect: > 1000 mg/kg
Compound 3: no number, only a limit; the forecaster's own chance of this, stated with the estimate: 5%; middle value at least 2.9-fold (0.46 log units) from the limit.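

The pair of compound 2 and compound 3 now isolates the change: in this assay, hydroxy in place of hydrogen on a saturated ring carbon, next to the ring nitrogen, gives an at least 5.4-fold higher number from compound 2 to compound 3 (0.73 log units; beyond the scatter), so more compound is needed once the hydroxy is present. The value of compound 3 is a limit of the assay and not a number, so the full size of the step cannot be read: the limit of > 1000 mg/kg in this assay, at which 1 of the 3 values shown sits. Compound 1 also carries the 5-hydroxy-2,4-dioxoimidazolidin-1-yl group and gives 743 mg/kg, so that group does not by itself rule out a measured number.

As far as these compounds go, whether any group on this carbon has the same effect as hydroxy stays open, for example a methyl, a methoxy or an amine. Also open, from the compounds shown here alone, is whether the step keeps its size with the nitrile of compound 1 in place of trifluoromethyl.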